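Shortening the amide chain within the shared core series

The source may report more compounds than this note shows. Statements on the series, on what has been measured and on what is new or still open speak of the compounds shown alone.

Among the compounds with values here, compound 2 `CCCCNC(=O)c1ccc2c(ccn2-c2ncc3c(n2)N(C2CCCC2)[C@H](CC)C(=O)N3C)c1` holds the lowest of the two numbers so far: in a functional assay on HeLa cells (Homo sapiens) for antiproliferative activity, read by CCK-8 assay, with a stated time of 72 h (a lower number here means a stronger inhibitor of growth, a higher number a weaker inhibitor of growth), compound 2 gives 346 nM, whereas compound 1 `CCC1C(=O)N(C)c2cnc(-n3ccc4cc(C(N)=O)ccc43)nc2N1c1ccn(C)n1` in this assay gives 27400 nM, a gap beyond the scatter. Compound 3 `CCNC(=O)c1ccc2c(ccn2-c2ncc3c(n2)N(C2CCCC2)[C@H](CC)C(=O)N3C)c1` differs from compound 2 in one place: hydrogen in place of ethyl on a saturated chain carbon, two bonds along the chain from an amide-type nitrogen. Within the data shown here, no measured pair shows this change, so its effect is unknown from the data. The step is expected to be small, at or near the edge of the scatter, and estimated as a 1.4-fold higher number from compound 2 to compound 3 (0.16 log units; within the scatter). In this assay compound 3 is expected near 500 nM, within a range of 150 nM to 1600 nM.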

Compound 3, concentration for 50% growth inhibition: 418 nM
Beside the measured number, compound 3's estimate is 1.2-fold (0.08 log units) above it, and the stated range covers the measured number.
By their numbers in this assay, from the lowest: compounds 2 and 3 (each within the scatter of the next); then compound 1.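

Going from butylamino to ethylamino gives a 1.2-fold higher number from compound 2 to compound 3 (0.08 log units; within the scatter) in this assay and is the first single-place comparison in the series. At this place on the chain, the ethyl can give way to hydrogen with no difference that this assay can separate from the scatter. Nothing measured on these compounds bears on the reason for this result.

Still open, as far as these compounds go, is how a methyl, a longer chain such as hexyl, or a chain carrying an amine or a carboxylic acid would read here, so the limits of this tolerance remain undefined.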